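The source may hold more compounds than are shown below. What is called first, only, known or untested is meant among the compounds shown, and "the series" means these compounds.

Compound 1 `COc1ccc(CN(c2cc(OC)c(OC)c(OC)c2)S(=O)(=O)c2ccc(C(C)(C)C)cc2)cc1`: 28600 nM
Compound 2 `COc1ccc(CN(c2cc(OC)c(OC)c(OC)c2)S(=O)(=O)c2ccc(OC)c(OC)c2)cc1`: 20100 nM

Among the measured compounds shown here, in a functional assay on PC-3 cells (Homo sapiens) for inhibition, read by MTT assay, with a stated time of 48 h (on this read-out higher numbers stand for weaker inhibition and lower numbers for stronger inhibition), compound 1 at 28600 nM and compound 2 at 20100 nM lie within the scatter of each other, so compound 1 stands level with the only other measured number. Compound 3 `COc1cc(N(Cc2nc3ccccc3[nH]2)S(=O)(=O)c2ccc(C(C)(C)C)cc2)cc(OC)c1OC` is still unmeasured. It departs from compound 1 as follows: 1H-benzimidazol-2-yl in place of 4-methoxyphenyl on a saturated chain carbon bound to a sulfonamide nitrogen. For the measured compounds named here, the one measured step, a 1.4-fold lower number from compound 1 to compound 2 (0.15 log units; within the scatter), lies on a sulfonyl sulfur and not at this place. Going by the values given here, no measured step covers the new group, so the size and direction of the change remain open, and no shift beyond the scatter can be expected with confidence in this assay. The expected step, a 1.8-fold lower number from compound 1 to compound 3 (0.25 log units; within the scatter), is therefore only tentative. For compound 3 the estimated value is 16000 nM, with an expected range of 4000 nM to 60000 nM.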

Compound 3, half-maximal inhibitory concentration: 29800 nM
Compound 3: the middle estimate sits 1.9-fold (0.27 log units) below what was measured; the range from low to high includes it.
By their numbers in this assay, from the lowest: compounds 2, 1 and 3 (each within the scatter of the next).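

In this assay, this position now has a measured step of its own: 1H-benzimidazol-2-yl in place of 4-methoxyphenyl on a saturated chain carbon bound to a sulfonamide nitrogen gives a 1.0-fold higher number from compound 1 to compound 3 (0.02 log units; within the scatter) and leaves the two compounds level. Among the compounds shown here, the swap brings in a five-membered aromatic ring with 2 hetero atoms and a hydrogen-bond donor, neither present in 4-methoxyphenyl, and still produces no step beyond the scatter, so this place joins the sulfonyl sulfur as a site with no separated step so far. No measurement is available that explains why the two groups read alike.

On these data alone, whether a carboxylic acid or a primary amine in place of 4-methoxyphenyl at this place would give a step beyond the scatter remains open. Also open, as far as these compounds go, is how 1H-benzimidazol-2-yl would read when paired with 3,4-dimethoxyphenyl on the sulfonyl sulfur.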